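The source may report more compounds than this note shows. Statements on the series, on what has been measured and on what is new or still open speak of the compounds shown alone.

Compound 1 `COC(=O)c1sc2c(C)cccc2c1Nc1cc(OC)c(OC)c(OC)c1` gives 1630 nM
Compound 2 `CCOC(=O)c1sc2ccccc2c1Nc1cc(OC)c(OC)c(OC)c1` gives 1900 nM

Both numbers come from a functional assay on SEM cells (Homo sapiens) for cytotoxicity, read by MTT assay, with a stated time of 72 h (on this read-out lower numbers stand for stronger inhibition and higher numbers for weaker inhibition), and lie within the usual scatter of each other, which places compound 2 level with compound 1. Compound 3 `COC(=O)c1sc2ccccc2c1Nc1cc(OC)c(OC)c(OC)c1` has not yet been measured. It differs from compound 2 in one place, where ethoxycarbonyl becomes methoxycarbonyl: hydrogen in place of methyl on a saturated chain carbon bound to an oxygen next to a carbonyl group. For the measured compounds named here, no measured pair shows this change alone. Compound 1 also carries methoxycarbonyl, though its core differs, and compound 1 at 1630 nM stays within the scatter of compound 2. In this assay the estimated step of a 1.4-fold lower number from compound 2 to compound 3 (0.13 log units; within the scatter) is expected to stay within the scatter too. The estimate for compound 3 is 1400 nM (expected range 450 nM to 4000 nM).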

Compound 3, half-maximal inhibitory concentration: 179 nM
Estimate against measurement, compound 3: 7.8-fold (0.89 log units) above; the measured number lies below the stated range.
By their numbers in this assay, from the lowest: compound 3; then compounds 1 and 2 (each within the scatter of the next).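

In this assay, the change from ethoxycarbonyl to methoxycarbonyl gives an 11-fold lower number from compound 2 to compound 3 (1.03 log units; beyond the scatter), so a single methyl on a saturated chain carbon bound to an oxygen next to a carbonyl group matters far more than the level values of the two earlier compounds suggested. Hydrogen in place of methyl on an aromatic carbon gives a 9.1-fold lower number from compound 1 to compound 3 (0.96 log units; beyond the scatter), which means that compound 3 is clearly the most potent of the three and that each of these two single methyl additions to it raises the number beyond the scatter. Nothing available explains why one methyl carries so much weight at either place.

As far as these compounds go, it remains open whether a carboxylic acid or a primary amide in place of methoxycarbonyl would hold this potency. From the compounds shown here alone, it is equally open how a fluorine or a methoxy group would behave on that aromatic carbon.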